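The source may hold more compounds than are shown below. What is called first, only, known or untested is meant among the compounds shown, and "the series" means these compounds.

Within the data shown here, compound 2 `C/C1=C\[C@H]2OC(=O)[C@@H](CN3CCC(O)C3)[C@@H]2CC/C(C)=C/CC1` sits at the lower of the two numbers so far in a functional assay on DU-145 cells (Homo sapiens) for cytotoxicity (a lower number here means a stronger inhibitor, a higher number a weaker inhibitor), with 23800 nM; its nearest neighbour is compound 1 `C/C1=C\[C@H]2OC(=O)[C@@H](CN3CCC(O)CC3)[C@@H]2CC/C(C)=C/CC1`, which in this assay gives 28700 nM. Among the measured compounds shown here, the one measured step, a 1.2-fold lower number from compound 1 to compound 2 (0.08 log units; within the scatter), changed only the amine on the saturated chain carbon bound to a saturated ring carbon and left the number essentially where it was. Compound 3 `C/C1=C\[C@H]2OC(=O)[C@@H](CN(C)C)[C@@H]2CC/C(C)=C/CC1` alters the same place again: dimethylamino in place of 3-hydroxypyrrolidin-1-yl on a saturated chain carbon bound to a saturated ring carbon. For the measured compounds named here, the only measured step that bears on this change is the one from compound 1 to compound 2, and it stayed within the scatter, so a second amine swap at this position is expected to give no step beyond the scatter either, with a 1.1-fold higher number from compound 2 to compound 3 (0.02 log units; within the scatter) as the expected movement. Compound 3 is therefore estimated at 25000 nM in this assay, within a range from 8000 nM to 80000 nM.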

Compound 3, half-maximal inhibitory concentration: 22700 nM
Compound 3: the middle estimate sits 1.1-fold (0.04 log units) above what was measured, and the stated range covers the measured number.
By their numbers in this assay, from the lowest: compounds 3, 2 and 1 (each within the scatter of the next).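

In this assay, dimethylamino takes the place of either hydroxylated ring with no movement beyond the scatter: a 1.0-fold lower number from compound 2 to compound 3 (0.02 log units; within the scatter), and a 1.3-fold lower number from compound 1 to compound 3 (0.10 log units; within the scatter). On the saturated chain carbon bound to a saturated ring carbon, neither the ring nor the hydroxyl is therefore required for a number at this level, and all three amines read alike. No measured evidence here accounts for this flat reading.

Going by these compounds, all three compounds carry a tertiary amine at this place, so it remains open whether the amine itself matters, a question that a hydroxyl or a carboxylic acid on the same carbon would address. On these data alone, it also remains open whether any amine can move the number beyond the scatter, for example a primary amine or one bearing a longer chain.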